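The compounds below may be only part of what the source reports. "The series", "measured", "known", "first", "only" and "open" are said of these compounds alone.

Measured compounds so far:

Compound 1 `Cc1nc(N)c2c(-c3ccccc3)cn([C@@H]3O[C@H](CO)[C@@H](O)[C@H]3O)c2n1` gives > 100000 nM in a functional assay on HCT-116 cells (Homo sapiens), read by MTT assay, with a stated time of 72 h; a lower number here means a stronger inhibitor, a higher number a weaker inhibitor; this is a limit of the assay, not a number.
Compound 2 `Cc1nc(N)c2c(-c3cccs3)cn([C@@H]3O[C@H](CO)[C@@H](O)[C@H]3O)c2n1` gives > 20000 nM in this assay; again a limit of the assay.
Compound 3 `CNc1ncnc2c1c(-c1ccccc1)cn2[C@@H]1O[C@H](CO)[C@@H](O)[C@H]1O` gives > 20000 nM in this assay; also a limit of the assay.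

Compound 1 and compound 2 differ in one place, (thiophen-2-yl in place of phenyl on an aromatic carbon). The step that the two limits leave unreadable from compound 1 to compound 2 cannot be sized, because the limit of > 100000 nM in this assay, at which 1 of the 3 values shown sits, and the limit of > 20000 nM in this assay, at which 2 of the 3 values shown sit, bracket the two values as limits on either side. Compound 3 shares its atoms with compound 1 but they are joined differently; the difference between the two cores is not broken down here.

Compound 4 `CNc1ncnc2c1c(-c1cccs1)cn2[C@@H]1O[C@H](CO)[C@@H](O)[C@H]1O` has not yet been measured in this assay. It stands to compound 3 as compound 2 stands to compound 1: thiophen-2-yl in place of phenyl on an aromatic carbon, and the surroundings of the place are the same in both pairs, so it is the same change. Among the measured compounds shown here, on the core of compound 3 the step is expected to be a step that the limit leaves unreadable from compound 3 to compound 4, which rests on three observations: compound 1 sits at the limit of > 100000 nM in this assay, at which 1 of the 3 values shown sits, compound 2 sits at the limit of > 20000 nM in this assay, at which 2 of the 3 values shown sit, and compound 3 sits at the limit of > 20000 nM in this assay, at which 2 of the 3 values shown sit, as well, so nothing among the measured compounds points to a readable gain from the change. For compound 4 the expected outcome in this assay is therefore 50000 nM, most likely reported again only as a limit, with a range of 15000 nM to 200000 nM.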

Compound 4, half-maximal inhibitory concentration: > 20000 nM
Compound 4: a limit, no number; the forecaster's own chance of this, stated with the estimate: 85%; the middle value lies beyond the limit too.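

In this assay compound 3 gives > 20000 nM, a limit of the assay and not a number. Compound 4 gives > 20000 nM, likewise a limit, so the change from phenyl to thiophen-2-yl between compound 3 and compound 4 cannot be sized. The compounds shown leave open whether this change alters the read-out on either core, since none of the four has a value beyond a limit.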